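The source may report more compounds than this note shows. Statements on the series, on what has been measured and on what is new or still open speak of the compounds shown alone.

Working notes on the series. The shared core of compound 1 `COCCS(=O)(=O)N1CCN(c2ccc(OCC3CCN(C(=O)OC(C)C)CC3)cn2)CC1` gives, in a functional assay on CHO-K1 cells for agonist activity at Glucose-dependent insulinotropic receptor (Homo sapiens), read by a luciferase reporter, with a stated time of 5 h (on this read-out higher numbers stand for an effect only at larger amounts of compound and lower numbers for an effect already at smaller amounts), a value of 300 nM. Compound 2 `CC(C)OC(=O)N1CCC(COc2ccc(N3CCN(S(=O)(=O)CC4CCCCC4)CC3)nc2)CC1` gives 90 nM; the step of a 3.3-fold lower number from compound 1 to compound 2 (0.52 log units; beyond the scatter) concerns the group on the sulfonyl side. Among the compounds with values here, compound 3 `CCCS(=O)(=O)N1CCN(c2ccc(OCC3CCN(C(=O)CC(C)C)CC3)cn2)CC1` gives 1600 nM, the highest number among the three measured compounds; compound 1 and compound 3 differ at two places at once, so their two values are only set side by side here, with no step counted between them.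

Compound 4 `CCCS(=O)(=O)N1CCN(c2ccc(OCC3CCN(C(=O)N4CCOCC4)CC3)cn2)CC1` differs from compound 3 by morpholin-4-yl in place of isobutyl on a carbonyl carbon. Within the data shown here, no measured step touches the carbonyl-bound group, so nothing in the numbers reads directly across to this change. Among the measured compounds shown here, the single step counted, a 3.3-fold lower number from compound 1 to compound 2 (0.52 log units; beyond the scatter), sits at the other end of the molecule and is of modest size; it gives a sense of the step sizes seen so far but not of their direction here. Compound 3 and compound 1 carry different carbonyl-bound groups and the lower number belongs to compound 1, which makes a moderate move in the same direction plausible for compound 4, though this rests on a single pair.

For compound 4 the expected value in this assay is 900 nM, within 300 nM to 2700 nM. The expected step is a 1.8-fold lower number from compound 3 to compound 4 (0.25 log units; within the scatter).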

Compound 4, half-maximal effective concentration: > 10000 nM
Compound 4: no number, only a limit (the forecaster's own chance of this, stated with the estimate: 5%); middle value at least 11-fold (1.04 log units) away from the limit.
By their numbers in this assay, from the lowest: compound 2; then compound 1; then compound 3. At a limit, above all of these: compound 4.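

The carbonyl-bound group now has a counted step of its own, and it is not a neutral place to make a change: with morpholin-4-yl in place of isobutyl on the carbonyl carbon, the series shows an at least 6.2-fold higher number from compound 3 to compound 4 (0.79 log units; beyond the scatter). Within the data shown here, until now the only counted step, a 3.3-fold lower number from compound 1 to compound 2 (0.52 log units; beyond the scatter), lay on the sulfonyl side, so this is the first sign that the opposite end of the molecule also moves the read-out, here towards effects only at larger amounts of compound. The reading for compound 4 is a limit of the assay and not a number: the limit of > 10000 nM in this assay, at which 1 of the 4 values shown sits.

The single change swaps an open isobutyl for a six-membered non-aromatic ring and adds a hydrogen-bond acceptor, and the compounds shown do not separate these two differences from each other. A piperidin-1-yl on the same carbonyl carbon would keep the ring without the ring oxygen, while a longer open alkyl chain there would add atoms without any ring, and neither group stands among the compounds shown.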